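Methylation of the hydroxymethyl group across two brominated catechol cores

This account rests on a few compounds, and the source may have more. Where it says the series, first, only, none or still open, it means among the compounds named here.

Compound 1 `OCc1cc(Br)c(O)c(O)c1Br` and compound 3 `OCc1cc(O)c(O)c(Br)c1Br` share the same atoms joined differently; how the two cores differ is not broken down here. In a functional assay on DLD-1 cells (Homo sapiens) for cytotoxicity, read by MTT assay, with a stated time of 96 h (a higher number here means a weaker inhibitor, a lower number a stronger inhibitor), compound 1 gives 15000 nM, and compound 3 gives 18300 nM, the two lying within the usual scatter of each other. Compound 2 `COCc1cc(Br)c(O)c(O)c1Br` is compound 1 with the change (methyl in place of hydrogen on an oxygen on a saturated carbon). This change made the step of a 2.1-fold lower number from compound 1 to compound 2 (0.31 log units; beyond the scatter), so in this assay compound 2 gives 7270 nM, a number beyond the scatter below that of compound 3 as well.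

Compound 4 `COCc1cc(O)c(O)c(Br)c1Br` is the unmeasured partner of compound 3 and carries the change (methyl in place of hydrogen on an oxygen on a saturated carbon). Among the measured compounds shown here, the place is the same in both pairs, an oxygen on a saturated carbon whose other neighbour is a saturated chain carbon, so this is the same change as the one from compound 1 to compound 2, made on the other core. Only one measured example of it exists among these compounds, and the cores are not compared in a counted way, so the expectation rests on that single step alone. For compound 4 in this assay the step is expected to be about a 2.0-fold lower number from compound 3 to compound 4 (0.31 log units; beyond the scatter), on the grounds of a 2.1-fold lower number from compound 1 to compound 2 (0.31 log units; beyond the scatter). Compound 4 is therefore estimated at 9000 nM, with a plausible range from 4500 nM to 19000 nM.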

Compound 4, half-maximal inhibitory concentration: 14600 nM
For compound 4 the middle estimate is 1.6-fold (0.21 log units) below the measured one; the range from low to high includes it.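

In this assay, the new step is a 1.3-fold lower number from compound 3 to compound 4 (0.10 log units; within the scatter), so on this core the methyl in place of hydrogen on an oxygen on a saturated carbon gives no shift that can be told apart from repeat scatter, unlike the step on the core of compound 1. Even so, the two steps cannot be called different when set side by side: the same change on two cores in this assay, a 2.1-fold lower number (0.31 log units; beyond the scatter) from compound 1 to compound 2 and a 1.3-fold lower number (0.10 log units; within the scatter) from compound 3 to compound 4, 1.6-fold (0.22 log units) apart, within the scatter of two such steps. The result therefore shows that carrying the change from the core of compound 1 to the core of compound 3 yields a step compatible with the earlier one, but it does not show that the two steps are equal or that the change lowers the number on the core of compound 3, and two pairs support no general rule for the series.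

The compounds shown leave open what a longer chain on the same oxygen, as in ethoxymethyl, or an amine or a carboxylic acid in place of the hydroxymethyl group would do in this assay. Also open, from the compounds shown here alone, is whether hydroxy to methoxy at this place gives a comparable step on other cores or in cells other than those used here.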